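The compounds below may be only part of what the source reports. "The series", "measured", "known", "first", "only" and "open" are said of these compounds alone.

In a functional assay on PC-3 cells (Homo sapiens) for cytotoxicity, read by MTT assay, with a stated time of 48 h (a higher number here means a weaker inhibitor, a lower number a stronger inhibitor), three compounds have been read so far. Compound 1 (`COc1ccc(-c2c[nH]c(=O)n2-c2cc(OC)c(OC)c(OC)c2)cc1OC`) gives > 50000 nM, which is a limit of the assay and not a number. Compound 2 (`COc1ccc(-c2cn(C(=O)Nc3cc(OC)c(OC)c(OC)c3)c(=O)n2-c2cc(OC)c(OC)c(OC)c2)cc1O`) also reports only a limit, > 50000 nM. Compound 3 (`COc1cc(-n2c(-c3ccccc3)cn(C(C)=O)c2=O)cc(OC)c1OC`) likewise reports only a limit, > 50000 nM. It therefore stands where every reading so far stands: the limit of > 50000 nM in this assay, at which 3 of the 3 values shown sit.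

Compound 4 (`COc1ccc(-c2cn(C(C)=O)c(=O)n2-c2cc(OC)c(OC)c(OC)c2)cc1`) departs from compound 3 in one place, phenyl to 4-methoxyphenyl: methoxy in place of hydrogen on an aromatic carbon. For the measured compounds named here, no measured pair in this assay shows what this change does, so the expectation is loose. Going by the values given here, with compound 3 reported as > 50000 nM, the only step that could appear as a number is expected to run toward stronger inhibition, of uncertain size, and compound 4 may well stay at the limit. The estimated change is an at least 3.3-fold lower number from compound 3 to compound 4 (0.52 log units; beyond the scatter). For compound 4 the estimated value is 15000 nM, with an expected range from 300 nM to 50000 nM.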

Compound 4, half-maximal inhibitory concentration: 19700 nM
Beside the measured number, compound 4's estimate is 1.3-fold (0.12 log units) below it; the measured number falls inside the stated range.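

In this assay, for the compounds shown here, methoxy in place of hydrogen on an aromatic carbon, para to a large group, yields the first reading in this set that is a number, with an at least 2.5-fold lower number from compound 3 to compound 4 (0.40 log units; beyond the scatter). As far as these compounds go, compound 3 gives > 50000 nM, which is a limit of the assay and not a number, so this step gives only a bound and its true size remains unknown. This single change is enough to bring compound 4 off the limit, and it is the only compound shown to leave it: the limit of > 50000 nM in this assay, at which 3 of the 4 values shown sit.

Whether this effect is specific to methoxy remains open, as neither an ethoxy group, a fluorine atom nor an amine is shown at this place. With a single step available, the compounds also leave open whether the same change would lower the number on any other compound.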